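A few compounds are considered here, and "the series" means these few. Any claim that something is new, unique, unknown or untested is made for them only; others in the source may bear on it.

Compound 1 (`O=C1CC(c2ccc(F)cc2)CN1c1cnn2c1CN(C(=O)Nc1cc(F)c(F)c(F)c1)C(C1CC1)C2`) and compound 2 (`O=C1CC(c2nccs2)CN1c1cnn2c1CN(C(=O)Nc1cc(F)c(F)c(F)c1)C(C1CC1)C2`) share one core and differ only in a single group. In a toxicity assay on HepG2 2.2.15 cells (Homo sapiens) for cytotoxicity, read by CellTiter-Glo (on this read-out higher numbers stand for lower toxicity in this test and lower numbers for higher toxicity in this test), compound 1 gives 32100 nM and compound 2 gives 115000 nM which is the higher of the two numbers, so compound 2 is the less toxic of this pair.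

Compound 3 (`Cc1nc(C2CC(=O)N(c3cnn4c3CN(C(=O)Nc3cc(F)c(F)c(F)c3)C(C3CC3)C4)C2)no1`) is not yet measured. It keeps everything in compound 2 except one group (5-methyl-1,2,4-oxadiazol-3-yl in place of 1,3-thiazol-2-yl on a saturated ring carbon) so 5-methyl-1,2,4-oxadiazol-3-yl stands in place of 1,3-thiazol-2-yl on a saturated ring carbon.

Among the measured compounds shown here, only one measured step bears on this change. It is a 3.6-fold higher number from compound 1 to compound 2 (0.55 log units; beyond the scatter) a modest move, seen when 1,3-thiazol-2-yl replaced 4-fluorophenyl at this same place. For the measured compounds named here, that single step offers thin guidance, and no measured compound yet carries the incoming group. Both groups in the new change are five-membered aromatic rings, so a smaller move than that one seems likely, with no clear direction.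

The expected result in this assay is a 1.1-fold higher number from compound 2 to compound 3 (0.04 log units; within the scatter) and this estimate stays close to the number for compound 2. Compound 3 is estimated at 125000 nM with an expected range from 50000 nM to 280000 nM as the likely span.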

Compound 3, half-maximal cytotoxic concentration: > 200000 nM
Compound 3: a limit, no number; the forecaster's own chance of this, stated with the estimate: 30%; middle value at least 1.6-fold (0.20 log units) from the limit.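

For compound 3 in this assay, the result is a limit and not a number: the limit of > 200000 nM in this assay, at which 1 of the 3 values shown sits.

Set against the 1,3-thiazol-2-yl group, the 5-methyl-1,2,4-oxadiazol-3-yl group gives an at least 1.7-fold higher number from compound 2 to compound 3 (0.24 log units; that floor lies within the scatter), so this floor does not firmly separate the two five-membered aromatic rings. Set against the 4-fluorophenyl group, the same ring gives an at least 6.2-fold higher number from compound 1 to compound 3 (0.79 log units; beyond the scatter), which is beyond the scatter, so a second five-membered aromatic ring on this saturated ring carbon also reads as less toxic in this test than the six-membered ring of compound 1.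

The limit leaves open how far compound 3 truly lies from compound 2, and so whether the 5-methyl-1,2,4-oxadiazol-3-yl group really improves on the 1,3-thiazol-2-yl group in this assay. All three groups shown here are aromatic rings, so the compounds shown cannot say how a non-aromatic group on this carbon, such as an amine or a carboxylic acid, would read in this test.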